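This account rests on a few compounds, and the source may have more. Where it says the series, first, only, none or still open, it means among the compounds named here.

Measured compounds:
compound 1 `Cc1cccc(/C(N)=N/NC(=S)N2CCN(c3ccccn3)CC2)n1` — 86.3%
compound 2 `N/C(=N\NC(=S)N1CCOCC1)c1ccccn1` — 87.2%
compound 3 `Cc1ccnc(/C(N)=N/NC(=S)N2CCOCC2)c1` — 82.7%

In a functional assay on HeLa cells (Homo sapiens) for cytotoxicity, read by MTT assay, with a stated time of 72 h, tested at 100 uM (a lower number here means less inhibition of growth, a higher number more inhibition of growth at the concentration tested), compound 2 gives 87.2%, the largest of the three numbers, but the gaps to compound 1 and to compound 3 are both within the usual scatter, so the three compounds are not separated by this read-out. Among the compounds with values here, the only single-site step measured, a number 4.5 percentage points lower from compound 2 to compound 3 (within the scatter), concerns a methyl on an aromatic carbon and lies within the scatter. Compound 1 differs from compound 2 in more than one place and its number is likewise within the scatter of compound 2.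

Compound 4 `N/C(=N\NC(=S)N1CCCCC1)c1ccccn1` differs from compound 2 in one place: piperidin-1-yl in place of morpholin-4-yl on a thiocarbonyl carbon. Within the data shown here, no measured step concerns this part of the molecule, so the expectation can rest only on the observation that every change seen so far left the read-out within the scatter, and the step of a number 2.2 percentage points lower from compound 2 to compound 4 (within the scatter) is expected to do the same. Compound 4 is therefore estimated at 85% in this assay, with a range from 70% to 95%.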

Compound 4, percent growth inhibition at one concentration: 86%
Estimate against measurement, compound 4: 1 percentage points below; the range from low to high includes it.
By their numbers in this assay, from the lowest: compounds 3, 4, 1 and 2 (each within the scatter of the next).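

Within the data shown here, on the thiocarbonyl carbon, piperidin-1-yl in place of morpholin-4-yl gives a number 1.2 percentage points lower from compound 2 to compound 4 (within the scatter) in this assay, the first measured change at this position. For this pair, the read-out does not separate the ring that carries the oxygen and its hydrogen-bond acceptor from the ring that carries neither. No available measurement speaks to what lies behind this outcome.

On these data alone, both numbers come from a single concentration, so whether compound 2 and compound 4 would separate at lower concentrations remains open. Also open, as far as these compounds go, is whether a different kind of group on the thiocarbonyl carbon, such as an open-chain diethylamino group or a piperidine ring bearing a carboxylic acid, would move the number beyond the scatter.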